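The compounds below may be only part of what the source reports. "The series", "measured", "known", "first", "only" and "open" are said of these compounds alone.

Among the measured compounds shown here, in a physicochemical assay for lipophilicity, read by HPLC, at pH 7.4 (on this read-out lower numbers stand for lower lipophilicity and higher numbers for higher lipophilicity), compound 2 (`Cc1c(F)cccc1C(=O)Nc1cc(Cl)ccn1`) stands lowest of the three measured compounds at 2.3 on the numbers so far. Compound 1 (`Cc1ccccc1C(=O)Nc1cc(Cl)ccn1`) sits higher at 3.4 and compound 3 (`Cc1ccccc1C(=O)Nc1ncccn1`) higher again at 3.9 on the same scale. The change from compound 2 to compound 4 (`Cc1ccnc(NC(=O)c2cccc(F)c2C)c1`) is methyl in place of chloro on an aromatic carbon and amounts to methyl in place of chloro on an aromatic carbon, opposite the ring nitrogen. For the measured compounds named here, the only measured step confined to one place, a number 1.10 log units lower from compound 1 to compound 2 (beyond the scatter) for fluoro in place of hydrogen, is large but lies at a different site, so it bears only indirectly and shows how far a single exchange can move this series. Going by the values given here, no measured step isolates the exchange of chloro for methyl. In this assay a small step down is therefore expected, at the edge of the scatter and well short of the fluoro step. The estimate amounts to a number 0.30 log units lower from compound 2 to compound 4 (within the scatter) as an expected move in this series. Compound 4 is estimated at 2 with an expected range of 1.5 to 2.6 when it is measured.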

Compound 4, distribution coefficient: 3.5
Compound 4: the middle estimate sits 1.50 log units below what was measured, outside the stated range (above it).
By their numbers in this assay, from the lowest: compound 2; then compounds 1 and 4 (each within the scatter of the next); then compound 3.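

In this assay the exchange of chloro for methyl opposite the ring nitrogen gives a number 1.20 log units higher from compound 2 to compound 4 (beyond the scatter) and so stands as a large step at this position in its own right. The position thus joins the fluoro exchange, a number 1.10 log units lower from compound 1 to compound 2 (beyond the scatter), as a second single change printed as large, at a different site and in the opposite direction. Nothing measured on the series accounts for the size or the direction of the step at this position.

From the compounds shown here alone, how an amine, a methoxy group or a nitrile at this position would read against chloro and methyl remains open. Also open, going by these compounds, is whether the same exchange gives a step of this size on the core of compound 1, which lacks the fluoro group.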